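This account rests on a few compounds, and the source may have more. Where it says the series, first, only, none or still open, it means among the compounds named here.

Measured in a functional assay on the whole organism (Abdomen, strain Swiss) for inhibition, with Mus musculus as the target, with stated times of 30 min, 10 min and 5 min, at a dose of 40 mg/kg by the oral route (on this read-out lower numbers stand for a weaker effect and higher numbers for a stronger effect at the one dose given), so far: compound 1 `Cc1c(C#N)c(-c2ccccc2)nn1CCCN1CCN(c2ccc(F)cc2)CC1` gives 51%; compound 2 `COc1cccc(N2CCN(CCCn3nc(-c4ccccc4)c(C#N)c3C)CC2)c1` gives 34%; compound 3 `Cc1ccc(N2CCN(CCCn3nc(-c4ccccc4)c(C#N)c3C)CC2)cc1` gives 30%.

Compound 3 holds the lowest of the three numbers, but one of the steps leading to it lies within the scatter (a number 4 percentage points lower from compound 2 to compound 3 (within the scatter)); only compound 1 stands clearly apart (a number 21 percentage points lower from compound 1 to compound 3 (beyond the scatter)). Compound 4 `Cc1c(C#N)c(-c2ccccc2)nn1CCCN1CCN(c2ccc([N+](=O)[O-])cc2)CC1` differs from compound 3 by nitro in place of methyl on an aromatic carbon. For the measured compounds named here, no measured step brings in a nitro group. Going by the values given here, the steps that bear on the change are those varying the group on the amine nitrogen in a ring: a number 21 percentage points lower from compound 1 to compound 3 (beyond the scatter), a number 17 percentage points lower from compound 1 to compound 2 (beyond the scatter) and a number 4 percentage points lower from compound 2 to compound 3 (within the scatter), the first two modest, the third within the scatter. A step of similar modest size in either direction is possible, but none beyond the scatter is expected: a number 5 percentage points higher from compound 3 to compound 4 (within the scatter). Compound 4 is therefore estimated at 35%, within 15% to 55%.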

Compound 4, a percentage reported as inhibition, in the whole organism at one dose (the size of the read-out at that dose, not a potency): 49%
Estimate against measurement, compound 4: 14 percentage points below; the range from low to high includes it.
By their numbers in this assay, from the lowest: compounds 3 and 2 (each within the scatter of the next); then compounds 4 and 1 (each within the scatter of the next).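

Nitro at this aromatic carbon separates compound 4 from the lower pair: (a number 19 percentage points higher from compound 3 to compound 4 (beyond the scatter)) and (a number 15 percentage points higher from compound 2 to compound 4 (beyond the scatter)). Against fluoro the change does not register (a number 2 percentage points lower from compound 1 to compound 4 (within the scatter)), so the two compounds with fluoro or nitro here sit together, above the methyl and 3-methoxyphenyl compounds. No measurement available here accounts for this split.

As far as these compounds go, whether chloro or an amine on the same aromatic carbon would fall with compound 1 and compound 4 or with compound 3 remains open. From the compounds shown here alone, whether this grouping holds at other doses also remains open.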